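This account rests on a few compounds, and the source may have more. Where it says the series, first, only, none or still open, it means among the compounds named here.

Compound 1, `COc1ccccc1Nc1nc(-c2cccc(F)c2)nc2ccc(F)cc12`, gives in a functional assay on HL-60 cells (Homo sapiens) for cytotoxicity, read by MTT assay, with a stated time of 48 h (on this read-out lower numbers stand for stronger inhibition and higher numbers for weaker inhibition), only a limit, > 50000 nM.
Compound 2, `Fc1cccc(-c2nc(Nc3ccccc3F)c3cc(F)ccc3n2)c1`, likewise gives only a limit, > 50000 nM, in this assay.
Compound 3, `Fc1cccc(-c2nc(Nc3ccc(Cl)cc3)c3cc(F)ccc3n2)c1`, gives 45700 nM in this assay.

Compound 3 thus stands as the only one of the three with a true number, the other two values being (the limit of > 50000 nM in this assay, at which 2 of the 3 values shown sit). The step of an at least 1.0-fold lower number from compound 1 to compound 3 (0.03 log units; that floor lies within the scatter) and the step of an at least 1.0-fold lower number from compound 2 to compound 3 (0.03 log units; that floor lies within the scatter) are each only floors, and both floors lie within the scatter, so neither shows a real gain. The step that the two limits leave unreadable from compound 1 to compound 2 cannot be read from two limits.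

Compound 4, `Fc1cccc(-c2nc(Nc3ccc(Br)cc3)c3cc(F)ccc3n2)c1`, differs from compound 3 by bromo in place of chloro on an aromatic carbon. For the measured compounds named here, no measured step alters this one atom on its own; the steps into compound 3 exchange the whole aryl group on the nitrogen, and they give only floors within the scatter. There is therefore no measured basis for expecting a shift beyond the scatter, and the step of a 1.0-fold lower number from compound 3 to compound 4 (0.01 log units; within the scatter) is estimated to stay within it. Compound 4 is expected to give about 45000 nM in this assay, within a range from 20000 nM to 100000 nM, with a fair chance that only a limit is reported.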

Compound 4, half-maximal inhibitory concentration: > 50000 nM
Compound 4: a limit, no number; the forecaster's own chance of this, stated with the estimate: 45%; middle value at least 1.1-fold (0.04 log units) away from the limit.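

For the compounds shown here, the change of chloro to bromo on an aromatic carbon, para to a large group, is the first measured step that alters this one atom alone, where the earlier steps exchanged the whole aryl group on the nitrogen. In this assay, from the compounds shown here alone, it gives an at least 1.0-fold higher number from compound 3 to compound 4 (0.03 log units; that floor lies within the scatter), so this floor shows no real change at this place, and the size of any true step stays unknown. The steps into compound 4 from the two compounds with other aryl groups on the nitrogen cannot be read, as both ends of each are limits, and with compound 4 the values gather further at one limit: the limit of > 50000 nM in this assay, at which 3 of the 4 values shown sit.

The compounds shown leave open whether any group at this place, such as an amine or a carboxylic acid in place of the halogen, would give a value clearly apart from the limit in this assay. Also open, going by these compounds, is whether a change elsewhere on the shared core, such as a longer chain or a nitrile in place of one of its fluoro groups, would give a true number at all.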